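The source may hold more compounds than are shown below. What is called first, only, known or untested is meant among the compounds shown, and "the series" means these compounds.

Measured so far in a functional assay on HL-60 cells (Homo sapiens) for activation, read by fluorescence and microscopy, with a stated time of 48 h; on this read-out lower numbers stand for an effect already at smaller amounts and higher numbers for an effect only at larger amounts of compound:

- Compound 1 `CCCC(CCC)C(=O)OC[C@H]1O[C@@H](n2cnc3c(N)ncnc32)[C@H](OC(=O)C(CCC)CCC)[C@]1(C)O`: 140000 nM
- Compound 2 `CCCC(CCC)C(=O)O[C@H]1[C@H](n2cnc3c(N)ncnc32)O[C@H](CO)[C@@]1(C)O`: "not active" (no number reported)

Going by the values given here, compound 1 carries the only number, so its place cannot be ranked against a second figure. Among the compounds with values here, the one other measured compound, compound 2, is recorded as "not active" (no number reported), and no number was reported for it. What compound 1 shows on its own is an effect that appears only at large amounts of compound.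

Compound 3 `CCCC(CCC)C(=O)OC[C@H]1O[C@@H](n2cnc3c(N)ncnc32)[C@H](O)[C@]1(C)O` has not yet been measured. It follows from compound 1 by a single change, hydrogen in place of (1-propylbutyl)carbonyl on an oxygen on a saturated carbon, which turns that position into a hydroxy group. Within the data shown here, no measured step gives the size of such a change, so any expectation is loose. The expected outcome in this assay is no shift beyond the usual scatter, and the step estimated is a 1.1-fold higher number from compound 1 to compound 3 (0.03 log units; within the scatter). A result without a number also remains possible, as the entry for compound 2 reads "not active" (no number reported). For compound 3 the estimated value is 150000 nM, with an expected range from 40000 nM to 500000 nM.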

Compound 3, concentration for half-maximal activity in the HL-60 assay: "not active" (no number reported)
Compound 3: no number reported; the estimate stays without a comparison.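

No step can be read from compound 1 to compound 3: in the HL-60 assay compound 3 is recorded as "not active" with no number, and in a physicochemical assay for metabolic stability, read by HPLC, in phosphate buffer, at 37 degrees C, at pH 7.4 (a higher number here means that the compound lasts longer, a lower number that the compound disappears faster), both compounds reach a limit of the assay rather than a number: the limit of > 72 h in the physicochemical assay, at which 2 of the 2 values shown sit.

In the physicochemical assay compound 1 gives > 72 h, which is a limit of the assay and not a number. In the physicochemical assay compound 3 gives > 72 h, which is likewise a limit of the assay and not a number.

The compounds shown leave open how far hydrogen in place of (1-propylbutyl)carbonyl shifts the cell read-out, and how long either compound lasts beyond that limit.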